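This account rests on a few compounds, and the source may have more. Where it says the series, first, only, none or still open, it means among the compounds named here.

Measured so far in a physicochemical assay for lipophilicity, at pH 7.4; a higher number here means a more lipophilic compound, a lower number a more polar compound:

Compound 1 `O=C(NC1CC1)C1CCN(c2cnccc2-c2ccccc2)CC1`: 2.5
Compound 2 `O=C(NC1CC1)C1CCN(c2cnccc2-c2ccccn2)CC1`: 1.3
Compound 3 `CCN(C)C(=O)C1CCN(c2cncnc2-c2ccccc2)CC1`: 2.1

Of these three, compound 2 has the lowest number, 1.3. Compound 3 is nearest to it and compound 1 furthest, and both gaps lie beyond the usual scatter of this assay.

Compound 4 `CN(C)C(=O)C1CCN(c2cnccc2-c2ccccn2)CC1` has not been measured yet. It differs from compound 2 in one place: dimethylamino in place of cyclopropylamino on a carbonyl carbon. Dimethylamino stands in place of cyclopropylamino on a carbonyl carbon.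

Going by the values given here, the only measured step, a number 1.20 log units lower from compound 1 to compound 2 (beyond the scatter), is large, but it concerns a group on an aromatic carbon, so it gives no direct guide to a change on the carbonyl carbon. Compound 3 differs from compound 2 in more than one place and cannot isolate this change either. With no measured evidence for a shift, none beyond the scatter is expected, and the estimated step is a number 0.10 log units lower from compound 2 to compound 4 (within the scatter). Compound 4 is expected to read 1.2, within an estimated range of 0.8 to 1.6.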

Compound 4, distribution coefficient: 1.2
Estimate against measurement, compound 4: no gap at the digits printed; the range from low to high includes it.
By their numbers in this assay, from the lowest: compounds 4 and 2 (each within the scatter of the next); then compound 3; then compound 1.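

In this assay, going by these compounds alone, dimethylamino in place of cyclopropylamino on a carbonyl carbon gives a number 0.10 log units lower from compound 2 to compound 4 (within the scatter), the first measured change at this position. On this core, then, the two groups cannot be told apart in this measurement, even though cyclopropylamino brings a three-membered ring and a hydrogen-bond donor and dimethylamino brings neither. Nothing at hand explains why the reading holds across this swap.

As far as these compounds go, whether the same swap gives the same result on the core of compound 1, which has phenyl where compound 2 has pyridin-2-yl, remains open. Also open, from the compounds shown here alone, is whether this position would stay as insensitive with a carboxylic acid, an amine carrying a charge, or a longer chain such as diethylamino on the carbonyl carbon.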